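Replacing 2,3-Dichlorophenyl with 4-Fluorophenyl

The source may report more compounds than this note shows. Statements on the series, on what has been measured and on what is new or still open speak of the compounds shown alone.

Compound 1 `S=c1oc(-c2ccc3c(c2)OCCO3)nn1CN1CCN(C(c2ccccc2)c2ccccc2)CC1` and compound 2 `S=c1oc(-c2ccc3c(c2)OCCO3)nn1CN1CCN(c2cccc(Cl)c2Cl)CC1` share a core and were tested in a functional assay on BGC-823 cells (Homo sapiens) for antiproliferative activity, read by MTT assay, with a stated time of 48 h; a lower number here means a stronger inhibitor, a higher number a weaker inhibitor. Compound 1 reads > 50000 nM, which is a limit of the assay and not a number. Among the measured compounds shown here, compound 2 gives 22600 nM, so far the only true number. Compound 3 `Fc1ccc(N2CCN(Cn3nc(-c4ccc5c(c4)OCCO5)oc3=S)CC2)cc1` carries 4-fluorophenyl in place of 2,3-dichlorophenyl on an amine nitrogen in a ring. For the measured compounds named here, no measured pair shows what this swap does, so only a small shift toward weaker activity, within the usual scatter, is expected: a 1.3-fold higher number from compound 2 to compound 3 (0.12 log units; within the scatter). The estimated value for compound 3 is 30000 nM, with an expected range of 13000 nM to 60000 nM.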

Compound 3, half-maximal inhibitory concentration: > 50000 nM
Compound 3: no number, only a limit (the forecaster's own chance of this, stated with the estimate: 30%); middle value at least 1.6-fold (0.22 log units) from the limit.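

Among the compounds shown here, putting 4-fluorophenyl in place of 2,3-dichlorophenyl on the amine nitrogen in the ring gives the first readable step in this assay, an at least 2.2-fold higher number from compound 2 to compound 3 (0.34 log units; beyond the scatter). Among these two aryl groups, only 2,3-dichlorophenyl gives a true number at this position. From the compounds shown here alone, the real size of the step stays unknown because compound 3 gives only a limit of the assay, not a number: the limit of > 50000 nM in this assay, at which 2 of the 3 values shown sit.

Open, going by these compounds, is whether a single chlorine, a methoxy group or an amine on that phenyl ring would give a readable value. These compounds also cannot separate the effect of losing the chlorines from that of gaining the fluorine.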